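Adding a Nitro Group to an Inactive Series

A few compounds are considered here, and "the series" means these few. Any claim that something is new, unique, unknown or untested is made for them only; others in the source may bear on it.

Compound 1 `Clc1ccc(Cc2nn3cc(-c4ccccc4)nc3s2)cc1` was tested in a functional assay on HeLa cells (Homo sapiens) for cytotoxicity, with a stated time of 72 h; on this read-out lower numbers stand for stronger inhibition and higher numbers for weaker inhibition. In this assay compound 1 gives > 250000 nM, which is a limit of the assay and not a measured number. Compound 2 `O=[N+]([O-])c1ccc(-c2cn3nc(Cc4ccc(Cl)cc4)sc3n2)cc1` differs from compound 1 by nitro in place of hydrogen on an aromatic carbon. In this assay compound 2 gives > 250000 nM, again a limit. The step that the two limits leave unreadable from compound 1 to compound 2 therefore has no readable size. Compound 3 `Clc1ccc(Cc2nn3c(Br)c(-c4ccccc4)nc3s2)cc1` is the third member of the set. In this assay compound 3 gives > 250000 nM, also a limit. The step that the two limits leave unreadable from compound 1 to compound 3 is equally unreadable, because of the limit of > 250000 nM in this assay, at which 3 of the 3 values shown sit.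

Compound 4 `O=[N+]([O-])c1ccc(-c2nc3sc(Cc4ccc(Cl)cc4)nn3c2Br)cc1` has not yet been measured. It differs from compound 3 by nitro in place of hydrogen on an aromatic carbon, the same change as from compound 1 to compound 2, made on a core that differs from the core of compound 1 by bromo in place of hydrogen on an aromatic carbon. The step that the limit leaves unreadable from compound 3 to compound 4 is expected to be small, because the matching step that the two limits leave unreadable from compound 1 to compound 2 left both partners at the limit. Compound 4 is therefore estimated to give 300000 nM, most likely reported only as a limit again.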

Compound 4, half-maximal inhibitory concentration: > 250000 nM
Compound 4: a limit, no number (the forecaster's own chance of this, stated with the estimate: 85%); the middle value lies beyond the limit too.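

In this assay compound 4 gives > 250000 nM, a limit of the assay and not a number. Neither the step from compound 3 to compound 4 nor the step from compound 2 to compound 4 can be read, because no compound has a measured number: the limit of > 250000 nM in this assay, at which 4 of the 4 values shown sit.

The compounds shown leave open whether nitro or bromo changes cytotoxicity at all.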